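Chain-end variation from compound 1 toward compound 4

The source may hold more compounds than are shown below. What is called first, only, known or untested is meant among the compounds shown, and "the series" means these compounds.

Of the compounds shown here, three sharing the piperidine-linked ester core have been measured in an in vitro functional assay on HEK ts201 cells for antagonist activity at Neuronal acetylcholine receptor; alpha4/beta2 (Homo sapiens), read by fluorescence and calcium flux; a lower number here means a stronger inhibitor, a higher number a weaker inhibitor. Compound 1 `CC1CC(=O)N(c2ccccc2C(=O)OCC2CCCN(CCCCOc3ccccc3)C2)C1=O` gives 1700 nM in this assay and stands lowest of the three. Compound 3 `O=C(OC1CCCN(C(=O)CCc2ccccc2)C1)c1ccccc1-c1ccccc1` gives 4300 nM, and compound 2 `O=C(OCC1CCCN(CCCc2ccccc2)C1)c1ccccc1N1C(=O)c2ccccc2C1=O` gives 5010 nM; both gaps to compound 1 lie beyond the scatter, so compound 1 is the strongest inhibitor of the set.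

Compound 4 `COc1ccc(OCCCCCN2CCCC(COC(=O)c3ccccc3N3C(=O)CC(C)C3=O)C2)cc1` differs from compound 1 in one place: (4-methoxyphenoxy)methyl in place of phenoxy on a saturated chain carbon, four bonds along the chain from an amine nitrogen in a ring. Within the data shown here, no measured pair isolates this change, so its effect cannot be read from the data; the two available comparisons (compounds 2 and 3 against compound 1) each change several features at once and offer no direct guidance.

With nothing to anchor a direction, the step is expected to be small. The estimated step of a 1.1-fold higher number from compound 1 to compound 4 (0.02 log units; within the scatter) is taken as staying within the scatter. Compound 4 is accordingly expected to give about 1800 nM in this assay, with a range of 700 nM to 5000 nM.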

Compound 4, half-maximal inhibitory concentration: 14500 nM
Compound 4: the middle estimate sits 8.1-fold (0.91 log units) below what was measured; the measured number lies above the stated range.
By their numbers in this assay, from the lowest: compound 1; then compounds 3 and 2 (each within the scatter of the next); then compound 4.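

In this assay, this chain position is sensitive to substitution: (4-methoxyphenoxy)methyl in place of phenoxy, on a saturated chain carbon, four bonds along the chain from an amine nitrogen in a ring, gives a weaker inhibitor (an 8.5-fold higher number from compound 1 to compound 4 (0.93 log units; beyond the scatter)). Among these compounds, this is the first comparison that differs in one place, and it shows that a change at the chain end alone can shift the number beyond the scatter. No measured evidence accounts for this step.

The two parts of the change, the added methoxy and the added chain length, remain unseparated here. Also open, from the compounds shown here alone, is how a shorter chain, or an amine or a carboxylic acid at the chain end, would read in this assay.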